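The source may report more compounds than this note shows. Statements on the series, on what has been measured and on what is new or still open speak of the compounds shown alone.

Measured compounds:

compound 1 `C=C1[C@@H](C/C=C2/C(=O)OC[C@H]2OC(C)=O)[C@]2(C)CC[C@@H](OC(C)=O)[C@@](C)(CO[Si](C)(C)C(C)(C)C)[C@H]2C[C@@H]1O` gives 6960 nM
compound 2 `C=C1[C@@H](OC(C)=O)C[C@@H]2[C@](C)(COC=O)[C@H](OC(C)=O)CC[C@@]2(C)[C@@H]1C[C@@H](Nc1ccc(O)cc1)C1=CCOC1=O` gives 18100 nM
compound 3 `C=C1[C@@H](OC(C)=O)C[C@@H]2[C@](C)(CO[Si](C)(C)C(C)(C)C)[C@H](OC(C)=O)CC[C@@]2(C)[C@@H]1C[C@@H](Nc1cccc(F)c1)C1=CCOC1=O` gives 3820 nM

All three were tested in a functional assay on MCF7 cells (Homo sapiens) for cytotoxicity, read by sulforhodamine B assay; a lower number here means a stronger inhibitor, a higher number a weaker inhibitor. Compound 1 stands second highest of the three numbers. Its nearest neighbour is compound 3, whose number lies within the usual scatter of compound 1, so no order between the two can be read. Compound 2 lies furthest away, with a number beyond the scatter above that of compound 1, so compound 2 is the weaker of that pair.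

The step to follow leads from compound 1 to the not yet measured compound 4 `C=C1CC[C@@H]2[C@](C)(CO[Si](C)(C)C(C)(C)C)[C@H](OC(C)=O)CC[C@@]2(C)[C@@H]1C/C=C1/C(=O)OC[C@H]1OC(C)=O`. The change is small: hydrogen in place of hydroxy on a saturated ring carbon. For the measured compounds named here, no pair among the measured compounds shows this same change, so there is no measured step to lean on. With only a hydroxy removed from a saturated ring carbon, the expected step of a 1.3-fold higher number from compound 1 to compound 4 (0.11 log units; within the scatter) in this assay is a small one, tending toward a weaker inhibitor, and it may well stay within the scatter. Compound 4 is therefore estimated at 9000 nM, with a likely range from 3000 nM to 27000 nM.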

Compound 4, half-maximal inhibitory concentration: 4840 nM
Compound 4: middle estimate off by 1.9-fold (0.27 log units), on the high side, within the range that was stated.
By their numbers in this assay, from the lowest: compounds 3, 4 and 1 (each within the scatter of the next); then compound 2.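

In this assay the swap of hydroxy for hydrogen on this saturated ring carbon gives a 1.4-fold lower number from compound 1 to compound 4 (0.16 log units; within the scatter) and so leaves no readable difference between the two compounds. For the compounds shown here, this pair is the only direct look at the position, and it shows that the hydroxy, with the one hydrogen-bond donor and one hydrogen-bond acceptor counted for it, can leave the core of compound 1 without a shift that rises above the scatter. Nothing shown here offers a measured reason for this outcome.

As far as these compounds go, one pair speaks for one background only, so it stays open whether the same swap would also leave the number within the scatter on the other compounds of this set, whose side chains differ from that of compound 1. Also open, from the compounds shown here alone, is what other groups on this ring carbon would do, such as a methoxy group, an amine or a carboxylic acid, any of which could give a step that goes beyond the scatter in either direction.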